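The source may hold more compounds than are shown below. What is called first, only, known or untested is meant among the compounds shown, and "the series" means these compounds.

Measured so far:
compound 1, `CNC(=O)c1oc2nc(-c3ccccc3)cc(C(F)(F)F)c2c1N`, 41200 nM
compound 2, `CNC(=O)c1oc2nc(-c3cccs3)cc(C(F)(F)F)c2c1N`, 12300 nM

In a functional assay on HepG2 cells (Homo sapiens) for antiproliferative activity, read by MTT assay (a lower number here means a stronger inhibitor, a higher number a weaker inhibitor), compound 2 gives the lower of the two numbers, and the step of a 3.3-fold lower number from compound 1 to compound 2 (0.52 log units; beyond the scatter) lies beyond the scatter. Compound 3, `Cc1ccc(/C=N/NC(=O)c2oc3nc(-c4cccs4)cc(C(F)(F)F)c3c2N)cc1`, differs from compound 2 by a group of 9 heavy atoms (8 carbon, 1 nitrogen; one six-membered aromatic ring of carbon only) in place of one carbon atom, on an amide-type nitrogen. For the measured compounds named here, no measured step touches this amide-type nitrogen; the only known step changed an aromatic ring elsewhere, so it offers no direct guide. Compound 3 is therefore expected to show only a modest step, a 2.5-fold lower number from compound 2 to compound 3 (0.39 log units; beyond the scatter), with a wide range, estimated at 5000 nM (from 1000 nM to 25000 nM).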

Compound 3, half-maximal inhibitory concentration: 19800 nM
Compound 3: the middle estimate sits 4.0-fold (0.60 log units) below what was measured, within the range that was stated.
By their numbers in this assay, from the lowest: compounds 2 and 3 (each within the scatter of the next); then compound 1.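

On the amide-type nitrogen, a group of 9 heavy atoms carrying a six-membered aromatic ring can stand in place of methyl, and in this assay the step, a 1.6-fold higher number from compound 2 to compound 3 (0.21 log units; within the scatter), leaves compound 2 and compound 3 unseparated. So this position accepts a far larger group without a difference that the assay can resolve. Nothing here gives a reason for this result. Still open, from the compounds shown here alone, is whether an amine or a carboxylic acid at this nitrogen would give a number beyond the scatter.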